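One Methoxy Added: Three Measured, One Expected

The source may report more compounds than this note shows. Statements on the series, on what has been measured and on what is new or still open speak of the compounds shown alone.

Compound 1 `COc1ccc(-c2cc(/C=C/C(=O)c3ccc(N)cc3)[nH]n2)cc1` gives 95% in a functional assay on NCI-H322M cells (Homo sapiens) for cytotoxicity, read by sulforhodamine B assay, with a stated time of 48 h, tested at 0.01 uM; a lower number here means a stronger effect, a higher number a weaker effect of the compound at the concentration tested. Compound 2 `COc1ccc(C(=O)/C=C/c2cc(-c3cc(OC)c(OC)c(OC)c3)n[nH]2)cc1OC` gives 94% in this assay. Compound 3 `COc1ccc(-c2cc(/C=C/C(=O)c3ccc(N)cc3)[nH]n2)cc1OC` gives 96% in this assay.

The three compounds share a common core, but the difference between the core of compound 1 and the core of compound 2 is not broken down here. Compound 1 and compound 3 differ in one place only: methoxy in place of hydrogen on an aromatic carbon. That change made a step of a number 1 percentage points higher from compound 1 to compound 3 (within the scatter), so the two numbers cannot be told apart.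

Compound 4 `COc1cc(C(=O)/C=C/c2cc(-c3cc(OC)c(OC)c(OC)c3)n[nH]2)cc(OC)c1OC` has not been measured. It arises from compound 2 by methoxy in place of hydrogen on an aromatic carbon. Going by the values given here, this is the same kind of change as the one from compound 1 to compound 3; the place differs in that the new methoxy group in compound 4 also sits meta to a methoxy group.

Because the earlier step was a number 1 percentage points higher from compound 1 to compound 3 (within the scatter), compound 4 is expected to give a number close to that of compound 2, with an estimated step of a number 1 percentage points higher from compound 2 to compound 4 (within the scatter). The estimate for compound 4 in this assay is 95%, with a range from 86% to 100%.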

Compound 4, a percentage reported as activity, at one concentration (the size of the read-out at that concentration, not a potency): 96%
Compound 4: the middle estimate sits 1 percentage points below what was measured, within the range that was stated.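

In this assay, the new step is a number 2 percentage points higher from compound 2 to compound 4 (within the scatter), so adding this methoxy group leaves two numbers that cannot be told apart. Set beside the earlier step, the same change reads alike on the two cores: the same change on two cores in this assay, a number 1 percentage points higher (within the scatter) from compound 1 to compound 3 and a number 2 percentage points higher (within the scatter) from compound 2 to compound 4, 1 percentage points apart, within the scatter of two such steps. Going by these compounds alone, this agreement shows only that the methoxy group made no difference that can be seen at this one concentration on these two cores; since neither step stands clear of the scatter, it does not show that the change would carry over to a core where a compound has a clear effect, and it says nothing about potency.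

From the compounds shown here alone, whether a different group in the same place, such as a carboxylic acid or a longer ethoxy chain, would move the number beyond the scatter remains open. Also open, going by these compounds, is how these compounds compare at higher concentrations, where a real difference between them might or might not appear.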